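Benzyl on the Methyl Arm of a Quinazoline Agonist

This account rests on a few compounds, and the source may have more. Where it says the series, first, only, none or still open, it means among the compounds named here.

Of the compounds shown here, three share one core and have been measured in an ADME assay on HEK293 cells for agonist activity at Toll-like receptor 8 (Homo sapiens), read by a luciferase reporter, with a stated time of 6 h; on this read-out lower numbers stand for an effect already at smaller amounts and higher numbers for an effect only at larger amounts of compound. Compound 1 `CCCC(C)Nc1nc(N)nc2ccccc12` gives 0.17 uM, compound 2 `CCCCNc1nc(N)nc2ccc(OC)cc12` gives 1.8 uM, and compound 3 `CCCCNc1nc(N)nc2cccc(C)c12` gives 0.3 uM. Among these, compound 3 stands second highest; its nearest neighbour is compound 1, whose number is within the scatter of that of compound 3, while compound 2 lies furthest from it, with a higher number that falls beyond the scatter.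

Compound 4 `CCCCNc1nc(N)nc2cccc(CCc3ccccc3)c12` has not been measured. It differs from compound 3 in one place, (benzyl in place of hydrogen on a saturated chain carbon bound to an aromatic carbon); cut one bond further out, the same change reads methyl to phenethyl.

Going by the values given here, no measured pair shows a change of this kind on this core, so the step can only be guessed from the spread of the three numbers. Compound 4 is expected to give 0.5 uM, within a range from 0.1 uM to 3 uM. The expected step of a 1.7-fold higher number from compound 3 to compound 4 (0.22 log units; within the scatter) is estimated as modest and likely within the scatter, in either direction.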

Compound 4, minimum effective concentration: 0.47 uM
Compound 4: middle estimate off by 1.1-fold (0.03 log units), on the high side, within the range that was stated.
By their numbers in this assay, from the lowest: compounds 1, 3 and 4 (each within the scatter of the next, the first and the last beyond it); then compound 2.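

In this assay, going by these compounds alone, the first change at this place on the shared core gives a 1.6-fold higher number from compound 3 to compound 4 (0.19 log units; within the scatter) and so stays within the scatter, and compound 3 and compound 4 cannot be told apart. Within the data shown here, the saturated chain carbon bound to an aromatic carbon thus carries a benzyl, with its 7 heavy atoms and six-membered aromatic ring, without a step beyond the scatter, something the earlier compounds could not show, since none of them formed a pair differing in one place. This rests on a single pair, and no measurement at hand offers a reason for the result.

From the compounds shown here alone, whether the same holds for a longer chain ending in the phenyl ring, or for a benzyl carrying an amine or a carboxylic acid, remains open. Also open, going by these compounds, is whether the benzyl would give a similar step alongside the branched chain of compound 1.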